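Thiosemicarbazones on fused heteroaryl aldehydes: antiproliferative series notes

The source may hold more compounds than are shown below. What is called first, only, known or untested is meant among the compounds shown, and "the series" means these compounds.

Measured so far:
- Compound 1, `S=C(N/N=C/c1ccc2ccccc2n1)Nc1ccc(Br)cc1`: 56800 nM
- Compound 2, `Cc1csc2sc(/C=N/NC(N)=S)c(C)c12`: 1120 nM
- Compound 3, `CN(C)C(=S)N/N=C/c1cc2cccnc2s1`: 48400 nM

All three compounds share the thiosemicarbazone linkage and were run in a functional assay on HeLa cells (Homo sapiens) for antiproliferative activity, read by sulforhodamine B assay, with a stated time of 72 h; a higher number here means a weaker inhibitor, a lower number a stronger inhibitor. Within this small set compound 3 sits at the second highest number; its nearest neighbour is compound 1, whose number is only marginally higher and lies within the scatter, so no order between compound 1 and compound 3 can be read from the data. Compound 2 stands far apart, with a number well below both and beyond the scatter.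

The next compound in the series is compound 4, `NC(=S)N/N=C/c1cc2cccnc2s1`. It keeps the core of compound 3 and differs in one place: amino in place of dimethylamino on a thiocarbonyl carbon. This brings the thiocarbonyl terminus of compound 4 to the same unsubstituted form found in compound 2, although the cores differ, so the comparison with compound 2 is suggestive only.

For the measured compounds named here, no step between measured compounds is available to calibrate this change. Compound 4 is expected to move to a lower number in this assay than compound 3, by an amount around a 6.1-fold lower number from compound 3 to compound 4 (0.78 log units; beyond the scatter), because compound 2 gives 1120 nM with the same terminus. The estimate for compound 4 is 8000 nM, with a range from 1500 nM to 40000 nM.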

Compound 4, half-maximal inhibitory concentration: 6290 nM
Compound 4: the middle estimate sits 1.3-fold (0.10 log units) above what was measured; the measured number falls inside the stated range.
By their numbers in this assay, from the lowest: compound 2; then compound 4; then compounds 3 and 1 (each within the scatter of the next).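

In this assay, the thiocarbonyl terminus on the core shared by compound 3 and compound 4 proves to be a position where a single change registers, with amino in place of dimethylamino giving a 7.7-fold lower number from compound 3 to compound 4 (0.89 log units; beyond the scatter). For the compounds shown here, this is the first step that isolates one change, since compound 1, compound 2 and compound 3 differ from one another in more than one place and their gaps could not be assigned to any single group. The result fixes the size of this change on this core only, and it separates compound 4 from compound 3, whereas compound 3 and compound 1 remained within the scatter of each other. No measurement at hand bears on what lies behind the step.

The compounds shown leave open whether methylamino, with one methyl on the terminal nitrogen, falls nearer to amino or to dimethylamino, and how a cyclic amine such as morpholine or a longer chain such as diethylamino would behave at this position. They also leave open whether the same change gives a step of similar size on the cores of compound 1 and compound 2.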